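Removing a Fluorine: Expected Effect on Cell Tolerance

This account rests on a few compounds, and the source may have more. Where it says the series, first, only, none or still open, it means among the compounds named here.

Compound 1, with the structure `CC(C)Cc1nn(-c2cccc(F)c2)cc1C(=O)NCc1ccc(F)cc1`, is tested in a toxicity assay on HepG2 2.2.15 cells (Homo sapiens) for cytotoxicity, read by CCK-8 assay, with a stated time of 8 days; a lower number here means that less compound is tolerated, a higher number that more compound is tolerated. In this assay compound 1 gives only a limit, > 100000 nM, not a number. A second compound, compound 2, built as `CC(C)Cc1nn(-c2nccs2)cc1C(=O)NCc1ccccc1F`, likewise reaches only a limit in this assay, > 100000 nM. Compound 1 therefore stands where every value shown stands, at the limit of > 100000 nM in this assay, at which 2 of the 2 values shown sit. Going by the values given here, no pair of measured compounds differing in a single place is available, so nothing measured yet shows how a small change moves the read-out.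

Compound 3, with the structure `CC(C)Cc1nn(-c2cccc(F)c2)cc1C(=O)NCc1ccccc1`, has not been measured. It differs from compound 1 in one place: hydrogen in place of fluoro on an aromatic carbon. A fluoro leaves an aromatic carbon of a six-membered aromatic ring of carbon only, para to a large group, and a hydrogen enters; seen one bond further out, 4-fluorobenzyl becomes benzyl.

With both measured compounds sitting at the limit, the expected step, a number no higher from compound 1 to compound 3 (the limit leaves the size open), is none beyond the scatter. Compound 3 is estimated at 100000 nM, with a range from 50000 nM to 200000 nM, and most likely the assay again reports only a limit.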

Compound 3, half-maximal cytotoxic concentration: 85900 nM
The estimate for compound 3 lay 1.2-fold (0.07 log units) above the measured number, and the stated range covers the measured number.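

In this assay, the change from 4-fluorobenzyl to benzyl comes with an at least 1.1-fold lower number from compound 1 to compound 3 (0.06 log units; that floor lies within the scatter), the first step among these compounds that can be read at all, though only as a floor. Going by these compounds alone, compound 3 gives 85900 nM, an actual number where the earlier compounds gave none, which shows that this scaffold can yield a measurable read-out with hydrogen on this aromatic carbon. The floor alone does not show that removing the fluoro matters, and the true size of the step stays unknown, as the other values are limits rather than numbers: the limit of > 100000 nM in this assay, at which 2 of the 3 values shown sit.

The compounds shown leave open how far the true value of compound 1 lies from that of compound 3, and so whether this position has any real bearing on how much compound the cells tolerate. They also do not tell what an amine, a carboxylic acid or a methoxy group on this same carbon would do to the number, or whether any such replacement would move it beyond the usual scatter.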